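A few compounds are considered here, and "the series" means these few. Any claim that something is new, unique, unknown or untested is made for them only; others in the source may bear on it.

Compound 1 `Nc1ncnn1/C(S)=N/Cc1ccccc1`: 40%
Compound 2 `C/N=C(\S)n1nnnc1N`: 53%
Compound 3 `C/N=C(\S)n1nc(-c2ccc(C#N)cc2)nc1N`: 87%

These three compounds have been tested in a functional assay on the whole organism for inhibition, with Rattus norvegicus as the target, at a dose of 30 mg/kg; a lower number here means less inhibition, a higher number more inhibition at the dose given (going by the name of the read-out). Compound 3 stands at the top of the numbers shown: its result in this assay is the highest of the three. Its gap to compound 2 is beyond the usual scatter of such measurements, and so is its larger gap to compound 1. Compound 3 is also the only one of the three that carries a six-membered aromatic ring of carbon only on the shared core.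

The next compound, compound 4 `C/N=C(\S)n1nc(-c2ccc(Br)cc2)nc1N`, keeps that ring and differs from compound 3 in one place: bromo in place of cyano on an aromatic carbon. Among the compounds with values here, no two measured compounds differ at this spot, so the size of the step in this assay is open. Without such a pair, a small downward step or none beyond the scatter is expected. Compound 4 is therefore estimated at 75%, within 50% to 95%. That estimate means an expected step of a number 12 percentage points lower from compound 3 to compound 4 (beyond the scatter) in this assay.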

Compound 4, a percentage reported as inhibition, in the whole organism at one dose (the size of the read-out at that dose, not a potency): 88%
The estimate for compound 4 lay 13 percentage points below the measured number; the range from low to high includes it.
By their numbers in this assay, from the lowest: compound 1; then compound 2; then compounds 3 and 4 (each within the scatter of the next).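

Within this assay the change from cyano to bromo on the aromatic carbon para to a large group gives a number 1 percentage points higher from compound 3 to compound 4 (within the scatter) and so leaves the read-out where it was. Within the data shown here, this is the first view of this spot: a group with a triple bond and a hydrogen-bond acceptor can give way to a single bromine atom with no such acceptor, so neither feature is needed here for a high number at this dose. Nothing available gives a reason why the two groups read alike.

As far as these compounds go, whether an amine or a carboxylic acid at this spot would hold the number remains open. The read-out also comes from one dose and is not a potency, so compound 3 and compound 4 could still part at other doses.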